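The source may hold more compounds than are shown below. What is called first, only, known or untested is meant among the compounds shown, and "the series" means these compounds.

Measured in a physicochemical assay for solubility, in phosphate buffer, at pH 7.4; on this read-out lower numbers stand for lower solubility and higher numbers for higher solubility:
- compound 1 `O=C(O)CCCCCNC(=O)NC1CCCCC1`: > 500000 nM
- compound 2 `COC(=O)CCCCCNC(=O)NC1CCCCC1`: > 500000 nM
- compound 3 `CC(C)[C@H](NC(=O)CCCNC(=O)NC1CCCCC1)C(=O)O`: > 500000 nM

All three entries are limits of the assay and not numbers. Compound 1 stands only at a limit, > 500000 nM, so there is no exact starting value.

The move to compound 4 `CC(C)[C@H](NC(=O)CCCCCNC(=O)NC1CCCCC1)C(=O)O` puts (1-carboxy-2-methylpropyl)amino in place of hydroxy on a carbonyl carbon.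

Among the compounds with values here, the one measured step, a step that the two limits leave unreadable from compound 1 to compound 2, has no size to carry over. The wider picture is the limit of > 500000 nM in this assay, at which 3 of the 3 values shown sit. Compound 3 carries the same entering group on a shorter chain, and it offers the closest comparison. With compound 3 at > 500000 nM, no step beyond the scatter is expected in this assay, in either direction, and another limit is the likeliest report for compound 4.

The expected change is a number no higher from compound 1 to compound 4 (the limit leaves the size open). For compound 4 the estimate is 500000 nM, with an expected range from 200000 nM to 700000 nM.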

Compound 4, solubility: > 500000 nM
Compound 4: no number, only a limit; the forecaster's own chance of this, stated with the estimate: 70%; the middle value sits exactly at the limit.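

In this assay compound 4 gives > 500000 nM, which is a limit and not a number. The steps to compound 4 from compound 1 and from compound 2 therefore cannot be read. How far the solubilities of these compounds differ stays open: the limit of > 500000 nM in this assay, at which 4 of the 4 values shown sit.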